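The source may hold more compounds than are shown below. What is called first, only, known or untested is meant among the compounds shown, and "the series" means these compounds.

Among the measured compounds shown here, compound 1 `Cc1nc(N)c2nc(O)n(Cc3ccccc3)c2n1` is one of three compounds measured in a functional assay (spleen, spleen) for activation, with Mus musculus as the target; a higher number here means that more compound is needed for the effect, a lower number that less compound is needed. In this assay compound 1 gives 1 uM, which places it second highest of the three numbers. Its nearest neighbour is compound 3 `Nc1ncnc2c1nc(O)n2Cc1ccc(Cl)cc1`, which gives 10 uM; the furthest is compound 2 `CCCSc1nc(N)c2nc(O)n(Cc3ccccc3)c2n1`, which gives 0.01 uM.

The unmeasured compound 4 `Nc1nc(SCc2ccccc2)nc2c1nc(O)n2Cc1ccccc1` differs from compound 1 in one place: benzylsulfanyl in place of methyl on an aromatic carbon. For the measured compounds named here, one measured step bears on this change, the one from compound 1 to compound 2, where propylsulfanyl replaces methyl on the same aromatic carbon, and that step was a 100-fold lower number from compound 1 to compound 2 (2.00 log units; beyond the scatter). Benzylsulfanyl, like propylsulfanyl, enters through a sulfur on that carbon, so a large step in the same direction is expected for compound 4, though the data give no step for benzylsulfanyl itself and the size is uncertain.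

Compound 4 is therefore estimated at 0.02 uM in this assay, with a range from 0.003 uM to 0.15 uM, an expected step of a 50-fold lower number from compound 1 to compound 4 (1.70 log units; beyond the scatter).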

Compound 4, minimum effective concentration: 0.1 uM
Beside the measured number, compound 4's estimate is 5.0-fold (0.70 log units) below it; the range from low to high includes it.
By their numbers in this assay, from the lowest: compound 2; then compound 4; then compound 1; then compound 3.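

In this assay, among the compounds shown here, benzylsulfanyl in place of methyl gives a 10-fold lower number from compound 1 to compound 4 (1.00 log units; beyond the scatter), so a second group entering through a sulfur on this aromatic carbon also lowers the number, which the single propylsulfanyl step could not show. What stands on the sulfur matters as well: phenyl in place of ethyl on the saturated chain carbon bound to the sulfur gives a 10-fold higher number from compound 2 to compound 4 (1.00 log units; beyond the scatter), so the sulfur alone does not set the number. Nothing measured here accounts for the gap between the two groups.

As far as these compounds go, what a propylamino or propoxy group on this aromatic carbon would give remains open, as does the effect of a longer chain on the sulfur, such as pentylsulfanyl. Also open, from the compounds shown here alone, is whether a chlorine on the phenyl ring of benzylsulfanyl would move the number.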